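Cyanoaziridine ureas on WiDr cells: nitro to fluoro

The source may report more compounds than this note shows. Statements on the series, on what has been measured and on what is new or still open speak of the compounds shown alone.

Three aryl ureas share one core. Compound 1 `N#CC1CN1C(=O)Nc1cccnc1` gives 18000 nM in a functional assay on WiDr cells (Homo sapiens) for inhibition; on this read-out higher numbers stand for weaker inhibition and lower numbers for stronger inhibition; compound 2 `N#CC1CN1C(=O)Nc1ccc([N+](=O)[O-])cc1` gives 3700 nM; compound 3 `N#CC1CN1C(=O)Nc1cccc2ccccc12` gives 2500 nM. Compound 2 thus holds the second highest number of the three, with compound 3 nearest and compound 1 furthest away, that gap lying beyond the scatter.

Compound 4 `N#CC1CN1C(=O)Nc1ccc(F)cc1` differs from compound 2 in one place: fluoro in place of nitro on an aromatic carbon. Among the compounds with values here, no measured pair shows this change, so the step is guessed. A small step toward weaker inhibition is expected, because compound 2 at 3700 nM already sits close to compound 3, and the expected move a 1.9-fold higher number from compound 2 to compound 4 (0.28 log units; within the scatter) may not exceed the scatter. Compound 4 is estimated at 7000 nM, within 2500 nM to 20000 nM.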

Compound 4, half-maximal inhibitory concentration: 9000 nM
Estimate against measurement, compound 4: 1.3-fold (0.11 log units) below, within the range that was stated.
By their numbers in this assay, from the lowest: compounds 3 and 2 (each within the scatter of the next); then compounds 4 and 1 (each within the scatter of the next).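

At this aromatic carbon, the series now has its first single-place comparison: in this assay, fluoro in place of nitro gives a 2.4-fold higher number from compound 2 to compound 4 (0.39 log units; beyond the scatter), a modest step beyond the scatter. The substituent at this position therefore matters to the read-out, with nitro giving the stronger inhibition of this pair. No supporting data bear on the reason for this step.

From the compounds shown here alone, whether an amine, a methoxy group or a carboxylic acid at this carbon would fall nearer compound 2 or compound 4 remains open. Also open, going by these compounds, is whether the same change gives a similar step on other aryl groups.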